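Leaving the 4,4-Difluorocyclohexyl Group

The source may report more compounds than this note shows. Statements on the series, on what has been measured and on what is new or still open speak of the compounds shown alone.

compound 1 `COc1ncc(-c2cc(OCC3CC3)c3nc(N)nc(C)c3c2)cc1NS(=O)(=O)c1ccc(F)cc1F` at 200 nM
compound 2 `COCCOc1cc(-c2cnc(OC)c(NS(=O)(=O)c3ccc(F)cc3F)c2)cc2c(C)nc(N)nc12` at 200 nM
compound 3 `COc1ncc(-c2cc(OC3CCC(F)(F)CC3)c3nc(N)nc(C)c3c2)cc1NS(=O)(=O)c1ccc(F)cc1F` at 83 nM

In a functional assay on NCI-H460 cells (Homo sapiens) for cytotoxicity, read by MTT assay, with a stated time of 96 h (a lower number here means a stronger inhibitor, a higher number a weaker inhibitor), compound 3 has the lowest number of the three, and its steps to the other two lie beyond the scatter. The unmeasured compound 4 `COc1ncc(-c2cc(OCC3CCOCC3)c3nc(N)nc(C)c3c2)cc1NS(=O)(=O)c1ccc(F)cc1F` has (oxan-4-yl)methyl in place of 4,4-difluorocyclohexyl on an oxygen on an aromatic ring, a difference that reads in full as (oxan-4-yl)methyl in place of 4,4-difluorocyclohexyl on an oxygen on an aromatic ring and that removes the group found only in compound 3.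

Going by the values given here, two measured steps bear most directly on this change: a 2.4-fold lower number from compound 1 to compound 3 (0.38 log units; beyond the scatter) and a 2.4-fold lower number from compound 2 to compound 3 (0.38 log units; beyond the scatter) are both modest, and each brings in 4,4-difluorocyclohexyl. A third, no change at the digits printed from compound 1 to compound 2 (within the scatter) links the two compounds without that group. Among the compounds with values here, the entering group resembles cyclopropylmethyl in compound 1 in ending in a methyl link and 2-methoxyethyl in compound 2 in holding an oxygen, although no measured compound carries the oxan-4-yl ring itself. A return towards their shared value is therefore expected, with a 2.2-fold higher number from compound 3 to compound 4 (0.34 log units; beyond the scatter) estimated in this assay as a modest rise. For compound 4 the expected value is 180 nM with 80 nM to 400 nM as the estimated range.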

Compound 4, half-maximal inhibitory concentration: 21 nM
For compound 4 the middle estimate is 8.6-fold (0.93 log units) above the measured one; measured number outside the range, below it.
By their numbers in this assay, from the lowest: compound 4; then compound 3; then compounds 1 and 2 (each within the scatter of the next).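

In this assay, going by these compounds alone, the group on this oxygen proves able to move the number much further than the earlier compounds suggested: keeping the saturated chain carbon, oxan-4-yl in place of cyclopropyl gives a 9.5-fold lower number from compound 1 to compound 4 (0.98 log units; beyond the scatter), and oxan-4-yl in place of methoxymethyl gives a 9.5-fold lower number from compound 2 to compound 4 (0.98 log units; beyond the scatter), although the exchange of those two groups had given no change at the digits printed from compound 1 to compound 2 (within the scatter). The 4,4-difluorocyclohexyl group also loses its place as the group giving the lowest number, with a 4.0-fold lower number from compound 3 to compound 4 (0.60 log units; beyond the scatter), so compound 4 now has the lowest number of the four, and its steps to all the others lie beyond the scatter. Nothing shown here offers an explanation for these differences.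

This last step changes the ring's two fluorine atoms to a single ring oxygen and adds a methyl link in one move, so the compounds shown leave the share of each change open. A cyclohexylmethyl group or an oxan-4-yl group placed directly on this oxygen would separate the two, and a piperidin-4-ylmethyl group would test whether a ring amine can stand in for the ring oxygen.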